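The compounds below may be only part of what the source reports. "The series", "measured", "known", "first", "only" and "open" are said of these compounds alone.

Compound 1 `COc1cc(-c2ncnn2-c2cccc(N)c2)cc(OC)c1OC` belongs to a small set tested in a functional assay on MCF7 cells (Homo sapiens) for antiproliferative activity, read by MTT assay, with a stated time of 72 h; a lower number here means a stronger inhibitor, a higher number a weaker inhibitor. In this assay compound 1 gives > 10000 nM, which is a limit of the assay and not a number. Compound 2 `COc1cc(-n2ncnc2-c2ccc(Cl)cc2)cc(OC)c1OC` was tested alongside it. In this assay compound 2 gives > 10000 nM, again a limit rather than a measured value. Going by the values given here, compound 1 therefore stands at no ranked position: both values shown sit at the limit of > 10000 nM in this assay, at which 2 of the 2 values shown sit, and no step between measured compounds that differ in one place can be drawn from them.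

Compound 3 `COc1cc(-c2ncnn2-c2ccccc2)cc(OC)c1OC` has not yet been measured. It differs from compound 1 in one place: hydrogen in place of amino on an aromatic carbon. Among the compounds with values here, with no measured step to lean on, the expectation rests on compound 1 alone. Because compound 1 sits at > 10000 nM as a limit, compound 3 is expected to remain near that limit. The step from compound 1 to compound 3 is expected as a step that the limit leaves unreadable from compound 1 to compound 3, not beyond the scatter. Compound 3 is estimated at 15000 nM, within 5000 nM to 50000 nM, most likely reported again only as a limit.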

Compound 3, half-maximal inhibitory concentration: > 10000 nM
Compound 3: only a limit was reported (the forecaster's own chance of this, stated with the estimate: 80%); the middle value is on the limit's open side.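

Compound 1 and compound 3 both rest on a limit of the assay and not on a number, so no step can be read between them: the limit of > 10000 nM in this assay, at which 3 of the 3 values shown sit. The compounds shown leave open whether hydrogen in place of amino changes activity at all, and what would bring a measurable value in this assay.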